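Swapping Fluoro for Dimethylamino in a Growth-Inhibition Series

This account rests on a few compounds, and the source may have more. Where it says the series, first, only, none or still open, it means among the compounds named here.

Of the compounds shown here, two that share a core have been tested so far in a functional assay on HL-60 cells (Homo sapiens) for inhibition; a higher number here means a weaker inhibitor of growth, a lower number a stronger inhibitor of growth. In this test, compound 1 (`COc1cc(/C=C/c2ccc(S(N)(=O)=O)cc2)cc(OC)c1`) gives 18600 nM, while compound 2 (`NS(=O)(=O)c1ccc(/C=C/c2ccc(F)cc2)cc1`) gives 37300 nM. These two values lie within the usual scatter of repeated measurements, so compound 2 stands level with compound 1 and the numbers cannot separate them.

Compound 3 (`CN(C)c1ccc(/C=C/c2ccc(S(N)(=O)=O)cc2)cc1`) has not yet been measured. Relative to compound 2, it has dimethylamino in place of fluoro on an aromatic carbon, para to a large group (dimethylamino in place of fluoro on an aromatic carbon).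

Among the measured compounds shown here, no measured pair differs in only one place, so the data do not show directly what a single swap does here. Still, compound 1 at 18600 nM and compound 2 at 37300 nM carry different groups and remain within the scatter, so only a small move is expected, towards a lower number and stronger growth inhibition. The estimated change is a 2.1-fold lower number from compound 2 to compound 3 (0.32 log units; beyond the scatter). Compound 3 is expected at 18000 nM, with an estimated range of 4000 nM to 60000 nM.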

Compound 3, concentration for 50% growth inhibition: > 100000 nM
Compound 3 gave a limit, no number; the forecaster's own chance of this, stated with the estimate: 10%; middle value at least 5.5-fold (0.74 log units) away from the limit.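

In this assay compound 3 gives > 100000 nM, which is a limit of the assay and not a number. Among the compounds shown here, this is the first change at a single place that can be read: on an aromatic carbon, para to a large group, dimethylamino in place of fluoro gives an at least 2.6-fold higher number from compound 2 to compound 3 (0.42 log units; beyond the scatter). So this position does not accept every group equally, and this swap weakens growth inhibition, though the printed step gives only the smallest size the change can have and its true size remains unknown: the limit of > 100000 nM in this assay, at which 1 of the 3 values shown sits.

The compounds shown leave open whether the weakening belongs to the nitrogen of dimethylamino or to its methyl groups, and a plain primary amine at the same carbon would help to separate those two readings. They also leave open whether a hydroxyl group or a carboxylic acid in this place would hold growth inhibition near that of compound 2 or lose it as compound 3 does.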